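A few compounds are considered here, and "the series" means these few. Any claim that something is new, unique, unknown or untested is made for them only; others in the source may bear on it.

Measured compounds in an assay on a protein complex for inhibition of CDK8/Cyclin C (Homo sapiens), with a stated time of 1 h; on this read-out higher numbers stand for weaker inhibition and lower numbers for stronger inhibition:
- compound 1 `CN1CCN(C(=O)/C=C/c2ccncc2-c2ccc3ccccc3c2)CC1`: 43.6 nM
- compound 2 `O=C(O)/C=C/c1ccncc1-c1ccc2ccccc2c1`: 5 nM
- compound 3 `COC1CN(C(=O)/C=C/c2ccncc2-c2ccc3ccccc3c2)C1`: 42.8 nM

Compound 3 stands second highest of the three numbers in this assay; its nearest neighbour is compound 1, a difference within the scatter (a 1.0-fold lower number from compound 1 to compound 3 (0.01 log units; within the scatter)), and its furthest is compound 2 (an 8.6-fold higher number from compound 2 to compound 3 (0.93 log units; beyond the scatter)).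

Compound 4 `O=C(O)CCNC(=O)/C=C/c1ccncc1-c1ccc2ccccc2c1` differs from compound 3 by (2-carboxyethyl)amino in place of 3-methoxyazetidin-1-yl on a carbonyl carbon. The two measured steps that bear on this change are those between the free acid and the amides: an 8.7-fold lower number from compound 1 to compound 2 (0.94 log units; beyond the scatter) and an 8.6-fold higher number from compound 2 to compound 3 (0.93 log units; beyond the scatter). Both show the free hydroxy on the carbonyl carbon giving a lower number than either ring-bearing amide, by a modest margin. Compound 4 keeps an amide on the carbonyl carbon but carries a carboxylic acid further out on the chain, so a number between the amides and the acid is expected, with a modest step downward in this assay estimated as a 2.1-fold lower number from compound 3 to compound 4 (0.33 log units; beyond the scatter). Compound 4 is therefore estimated at 20 nM, within a range of 6 nM to 70 nM.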

Compound 4, half-maximal inhibitory concentration: 870 nM
Compound 4: the middle estimate sits 44-fold (1.64 log units) below what was measured; measured number above the stated range.
By their numbers in this assay, from the lowest: compound 2; then compounds 3 and 1 (each within the scatter of the next); then compound 4.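

On the carbonyl carbon, in this assay, (2-carboxyethyl)amino sets compound 4 clearly apart from the two ring-bearing amides (a 20-fold higher number from compound 3 to compound 4 (1.31 log units; beyond the scatter); a 20-fold higher number from compound 1 to compound 4 (1.30 log units; beyond the scatter)), which had stood within the scatter of each other. The carboxylic acid inside this group does not reproduce the effect of hydroxy on the carbonyl carbon (a 170-fold higher number from compound 2 to compound 4 (2.24 log units; beyond the scatter)), so the low number of compound 2 does not carry over to an amide that merely contains a carboxylic acid. Nothing in hand accounts for the size of these steps.

From the compounds shown here alone, it remains open whether the rise follows the open chain or the carboxylic acid, which a simple open-chain amide such as methylamino or 2-methoxyethylamino would separate. Also open, going by these compounds, is how a shorter or longer chain bearing the carboxylic acid would read in this assay.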